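Aryl tail changes and cytotoxicity in one series

This account rests on a few compounds, and the source may have more. Where it says the series, first, only, none or still open, it means among the compounds named here.

Among the measured compounds shown here, compound 3 `C=C/C=C\[C@H](C)[C@H](OC(N)=O)[C@@H](C)[C@H](O)[C@@H](C)C/C(C)=C\[C@H](C)[C@@H](O)[C@@H](C)/C=C\CCc1ccc(C)c(F)c1` gives 1000 nM in a functional assay on MCF7 cells (Homo sapiens) for cytotoxicity (a higher number here means a weaker inhibitor, a lower number a stronger inhibitor), the highest of the three numbers so far. Compound 1 `C=C/C=C\[C@H](C)[C@H](OC(N)=O)[C@@H](C)[C@H](O)[C@@H](C)C/C(C)=C\[C@H](C)[C@@H](O)[C@@H](C)/C=C\CCc1ccsc1` gives 850 nM; the step of a 1.2-fold higher number from compound 1 to compound 3 (0.07 log units; within the scatter) is within the scatter. Compound 2 `C=C/C=C\[C@H](C)[C@H](OC(N)=O)[C@@H](C)[C@H](O)[C@@H](C)C/C(C)=C\[C@H](C)[C@@H](O)[C@@H](C)/C=C\CCc1cccc(OC)c1` gives 330 nM, and the step of a 3.0-fold higher number from compound 2 to compound 3 (0.48 log units; beyond the scatter) is beyond the scatter, so compound 2 holds the lowest number. Compound 4 `C=C/C=C\[C@H](C)[C@H](OC(N)=O)[C@@H](C)[C@H](O)[C@@H](C)C/C(C)=C\[C@H](C)[C@@H](O)[C@@H](C)/C=C\CCc1ccc(C)c(O)c1` differs from compound 3 by hydroxy in place of fluoro on an aromatic carbon. For the measured compounds named here, the steps that bear on this change are a 2.6-fold lower number from compound 1 to compound 2 (0.41 log units; beyond the scatter) and a 3.0-fold higher number from compound 2 to compound 3 (0.48 log units; beyond the scatter), both modest, with the 3-methoxyphenyl tail giving the lower number. A hydroxy tail is expected to behave nearer the 3-methoxyphenyl case than the fluoro case, so a modest lowering is expected, a 2.0-fold lower number from compound 3 to compound 4 (0.30 log units; within the scatter). Compound 4 is estimated at 500 nM, range 200 nM to 1300 nM.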

Compound 4, half-maximal inhibitory concentration: 770 nM
The estimate for compound 4 lay 1.5-fold (0.19 log units) below the measured number; the measured number falls inside the stated range.
By their numbers in this assay, from the lowest: compound 2; then compounds 4, 1 and 3 (each within the scatter of the next).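

Hydroxy in place of fluoro, ortho to a methyl group, brings a 1.3-fold lower number from compound 3 to compound 4 (0.11 log units; within the scatter) in this assay and so no readable change at this position, despite the added hydrogen-bond donor and acceptor. The 3-hydroxy-4-methylphenyl tail also sits level with thiophen-3-yl, with a 1.1-fold lower number from compound 1 to compound 4 (0.04 log units; within the scatter) within the scatter, while a 2.3-fold higher number from compound 2 to compound 4 (0.37 log units; beyond the scatter) keeps the 3-methoxyphenyl tail apart. Nothing available accounts for these steps.

As far as these compounds go, whether an amine or a carboxylic acid on this same aromatic carbon would depart from hydroxy and fluoro stays open. So does the part played by the methyl group.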